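Swapping a thiazole amide for a chlorophenyl amide

The source may hold more compounds than are shown below. What is called first, only, known or untested is meant among the compounds shown, and "the series" means these compounds.

Compound 2 `Cc1nc(C(=O)Nc2ccc(Cl)c(-c3nnc4c(Cl)cccn34)c2)cs1` is one of three amides built on a shared core. In a functional assay on T47D cells (Homo sapiens) for antiproliferative activity, read by MTT assay, with a stated time of 72 h (a higher number here means a weaker inhibitor, a lower number a stronger inhibitor), compound 2 gives > 100000 nM, which is a limit of the measurement rather than a number. Compound 1 `CS(=O)(=O)c1ccc(C(=O)Nc2ccc(Cl)c(-c3nnc4c(Cl)cccn34)c2)c(Cl)c1` likewise gives > 100000 nM, also a limit. Compound 3 `O=C(Nc1ccc(Cl)c(-c2nnc3c(Cl)cccn23)c1)c1ccccc1Cl` gives 83800 nM. Both measured steps, an at least 1.1-fold lower number from compound 1 to compound 3 (0.07 log units; that floor lies within the scatter) and an at least 1.1-fold lower number from compound 2 to compound 3 (0.07 log units; that floor lies within the scatter), stay within the scatter, and the limit of > 100000 nM in this assay, at which 2 of the 3 values shown sit, leaves their true size open. Compound 4 `O=C(Nc1ccc(Cl)c(-c2nnc3c(Cl)cccn23)c1)c1ccc(Cl)cc1` differs from compound 2 by 4-chlorophenyl in place of 2-methyl-1,3-thiazol-4-yl on a carbonyl carbon. Since the closest measured change an at least 1.1-fold lower number from compound 2 to compound 3 (0.07 log units; that floor lies within the scatter) was at most a small movement, the expected step of an at least 1.1-fold lower number from compound 2 to compound 4 (0.04 log units; that floor lies within the scatter) is small too, with no direction beyond the scatter. Compound 4 is therefore estimated to give about 90000 nM, within 30000 nM to 300000 nM.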

Compound 4, half-maximal inhibitory concentration: > 100000 nM
Compound 4 gave a limit, no number (the forecaster's own chance of this, stated with the estimate: 55%); middle value at least 1.1-fold (0.04 log units) away from the limit.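

From the compounds shown here alone, on the carbonyl carbon, 4-chlorophenyl in place of 2-chlorophenyl gives an at least 1.1-fold higher number from compound 3 to compound 4 (0.07 log units; that floor lies within the scatter) in this assay, so moving the chlorine around this ring shows no difference beyond the scatter, though the true size stays open. Compound 4 gives a limit, not a number, and the step from compound 2 cannot be read; most of the set now sits at the same limit: the limit of > 100000 nM in this assay, at which 3 of the 4 values shown sit.

Going by these compounds, what an aminophenyl or a carboxylic acid-bearing phenyl would do on this carbonyl carbon remains open. So does whether any amide of the shared core can move clearly away from that limit.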